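Methylamino in Place of Pyrrolidinyl: an Expected Gain

A few compounds are considered here, and "the series" means these few. Any claim that something is new, unique, unknown or untested is made for them only; others in the source may bear on it.

Compound 1 `COC(C)(C)CCOc1cccc2ccc(N)nc12`: 4670 nM
Compound 2 `CC(CC(C)(C)C)Oc1cccc2ccc(N3CCCC3)nc12`: > 10000 nM

In a functional assay on IMR-32 cells with melanin-concentrating hormone receptor 1 (Homo sapiens) as the target, read by fluorescence (a lower number here means a stronger inhibitor, a higher number a weaker inhibitor), compound 1 gives 4670 nM. For compound 2 the outcome in this assay is only a limit, > 10000 nM, so compound 2 sits at the limit of > 10000 nM in this assay, at which 1 of the 2 values shown sits, without a number of its own. Compound 3 `CNc1ccc2cccc(OC(C)CC(C)(C)C)c2n1` differs from compound 2 by methylamino in place of pyrrolidin-1-yl on an aromatic carbon. Among the compounds with values here, no measured step joins the two. Compound 1, which carries an amino group, gives 4670 nM in this assay. Compound 3 is therefore expected to move from the limit by an at least 2.0-fold lower number from compound 2 to compound 3 (0.30 log units; that floor lies within the scatter) in this assay. Compound 3 is estimated at 5000 nM, between 1500 nM and 20000 nM.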

Compound 3, half-maximal inhibitory concentration: 6090 nM
Compound 3: the middle estimate sits 1.2-fold (0.09 log units) below what was measured; low and high end bracket the measured number.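

In this assay, methylamino in place of pyrrolidin-1-yl on the aromatic carbon next to the ring nitrogen gives an at least 1.6-fold lower number from compound 2 to compound 3 (0.21 log units; that floor lies within the scatter). With this change, the core carrying this ether chain returns a number of its own, yet the step cannot be shown to exceed the usual scatter. Its true size stays unknown, as compound 2 has only a limit: the limit of > 10000 nM in this assay, at which 1 of the 3 values shown sits.

Going by these compounds, whether dimethylamino, ethylamino or piperidin-1-yl at this position would read differently stays open. So does the effect of a plain amino group on the ether chain of compound 3.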